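Chloro for hydroxy on the aryl ketone of compound 2

A few compounds are considered here, and "the series" means these few. Any claim that something is new, unique, unknown or untested is made for them only; others in the source may bear on it.

Within the data shown here, compound 2 `O=C(/C=C/c1cc2ccccc2[nH]c1=O)c1ccc(O)cc1` stands highest of the two numbers so far in a functional assay on SF-295 cells (Homo sapiens) for cytotoxicity, read by sulforhodamine B assay, with a stated time of 24 h (a higher number here means a weaker inhibitor of growth, a lower number a stronger inhibitor of growth), where compound 2 gives 44000 nM. Among the measured compounds shown here, its only neighbour, compound 1 `COc1ccc(C(=O)/C=C/c2cc3ccccc3[nH]c2=O)cc1`, gives 18600 nM in this assay, the step being a 2.4-fold higher number from compound 1 to compound 2 (0.37 log units; beyond the scatter). Compound 3 `O=C(/C=C/c1cc2ccccc2[nH]c1=O)c1ccc(Cl)cc1` carries the change (chloro in place of hydroxy on an aromatic carbon). For the measured compounds named here, no measured step replaces hydroxy with chloro; the single known step concerns methyl against hydrogen on the oxygen, so it bears only loosely. Since compound 1, which also lacks the hydroxy, gives 18600 nM, compound 3 is expected to fall back to a comparable number, a step of a 2.2-fold lower number from compound 2 to compound 3 (0.34 log units; beyond the scatter). Compound 3 is estimated at 20000 nM, range 8000 nM to 50000 nM.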

Compound 3, concentration for total growth inhibition: 38300 nM
Compound 3: the middle estimate sits 1.9-fold (0.28 log units) below what was measured; low and high end bracket the measured number.
By their numbers in this assay, from the lowest: compound 1; then compounds 3 and 2 (each within the scatter of the next).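

In this assay, chloro in place of hydroxy gives a 1.1-fold lower number from compound 2 to compound 3 (0.06 log units; within the scatter), so 4-hydroxyphenyl and 4-chlorophenyl are not separated at this position. Chloro in place of methoxy gives a 2.1-fold higher number from compound 1 to compound 3 (0.31 log units; beyond the scatter), so removing the hydroxy does not by itself reach the number of compound 1; among these three compounds, only the methoxy group stands apart. No evidence is available to explain this pattern.

On these data alone, whether an amine, a carboxylic acid or a longer alkoxy chain at this position would stay with compound 1 or with compounds 2 and 3 remains open.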